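The source may report more compounds than this note shows. Statements on the series, on what has been measured and on what is new or still open speak of the compounds shown alone.

Compound 1 `COc1ccc(-c2cn(C(=O)Nc3cc(OC)c(OC)c(OC)c3)c(=O)n2-c2cc(OC)c(OC)c(OC)c2)cc1`: 3800 nM
Compound 2 `COc1ccc(-c2cn(C(=O)Nc3cc(OC)c(OC)c(OC)c3)c(=O)n2-c2cc(OC)c(OC)c(OC)c2)cc1N`: 5800 nM
Compound 3 `COc1cc(-n2c(-c3ccc(Br)cc3)cn(C(C)=O)c2=O)cc(OC)c1OC`: 1000 nM

All three values come from a functional assay on K562 cells (Homo sapiens) for cytotoxicity, read by MTT assay, with a stated time of 48 h; a lower number here means a stronger inhibitor, a higher number a weaker inhibitor. Compound 3 has the lowest number of the three, 1000 nM, and its gaps to the other two lie beyond the usual scatter.

Compound 4 `COc1ccc(-c2cn(C(C)=O)c(=O)n2-c2cc(OC)c(OC)c(OC)c2)cc1` has not yet been measured. It differs from compound 3 in one place: methoxy in place of bromo on an aromatic carbon. Methoxy stands in place of bromo on an aromatic carbon, so 4-bromophenyl becomes 4-methoxyphenyl.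

Among the measured compounds shown here, no measured step makes this exact swap. For the measured compounds named here, the only step with a single change is a 1.5-fold higher number from compound 1 to compound 2 (0.18 log units; within the scatter). It puts amino in place of hydrogen on the ring that carries the methoxy, so it offers only a loose hint that a change on this ring may do little. Compound 1 already carries the 4-methoxyphenyl group and gives 3800 nM, a higher number than compound 3, but the two also differ elsewhere, so this comparison cannot isolate the swap. A modest move towards a higher number in this assay is therefore expected, with no firm expectation of a step beyond the scatter. The expected step is a 1.6-fold higher number from compound 3 to compound 4 (0.20 log units; within the scatter). Compound 4 is estimated at 1600 nM, with an expected range from 550 nM to 4800 nM.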

Compound 4, half-maximal inhibitory concentration: 200 nM
Compound 4: middle estimate off by 8.0-fold (0.90 log units), on the high side; measured number below the stated range.
By their numbers in this assay, from the lowest: compound 4; then compound 3; then compounds 1 and 2 (each within the scatter of the next).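

In this assay, replacing bromo with methoxy on an aromatic carbon, para to a large group, gives a 5.0-fold lower number from compound 3 to compound 4 (0.70 log units; beyond the scatter), a change clearly beyond the scatter. Among the compounds shown here, this shows that the group at this position can make a real difference to the cytotoxicity read-out, something the earlier compounds could not show: their only single-change step, a 1.5-fold higher number from compound 1 to compound 2 (0.18 log units; within the scatter), put amino in place of hydrogen elsewhere on the same ring and stayed within the scatter. No supporting measurement is available to explain why going from 4-bromophenyl to 4-methoxyphenyl lowers the number.

For the compounds shown here, this comparison covers only two groups at this position, so it remains open how an unsubstituted phenyl, a chlorine or fluorine atom, a hydroxyl, an ethoxy group or an amine placed there would compare with methoxy. It is also unknown whether the same swap would lower the number in a compound carrying the larger side group of compound 1, since no bromo partner of that compound is shown, and this single pair cannot establish a general trend.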